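A few compounds are considered here, and "the series" means these few. Any claim that something is new, unique, unknown or untested is made for them only; others in the source may bear on it.

Compound 2, `COc1cc2ncnc(Nc3ccc(Cl)cc3)c2cc1OCCCCC(=O)Nc1ccc(S(N)(=O)=O)cc1`, carries a chloro on its aniline ring where compound 1, `COc1cc2ncnc(Nc3ccc(Cl)c(C(F)(F)F)c3)c2cc1OCCCCC(=O)Nc1ccc(S(N)(=O)=O)cc1`, carries both chloro and trifluoromethyl. In a functional assay on A549 cells (Homo sapiens) for antiproliferative activity, read by MTT assay, with a stated time of 72 h (on this read-out higher numbers stand for weaker inhibition and lower numbers for stronger inhibition), compound 1 gives 9270 nM. In this assay compound 2 gives only a limit, > 40000 nM, so its true number is not known. Going by the values given here, the one measured step, an at least 4.3-fold higher number from compound 1 to compound 2 (0.63 log units; beyond the scatter), concerns the trifluoromethyl and therefore bears on a different position than the change now followed; it shows only that the number of compound 2 lies beyond what the assay resolves, as the limit of > 40000 nM in this assay, at which 1 of the 2 values shown sits, records. Compound 3, `COc1ccc(Nc2ncnc3cc(OC)c(OCCCCC(=O)Nc4ccc(S(N)(=O)=O)cc4)cc23)cc1`, differs from compound 2 by methoxy in place of chloro on an aromatic carbon. No measured pair reports a chloro-to-methoxy exchange, so no size of step in this assay can be drawn from the data shown. Since compound 2 already sits at the limit, a further rise would stay unseen, and a fall would have to be large to give a number. The expected step, a step that the limit leaves unreadable from compound 2 to compound 3, is set near zero. Compound 3 is therefore estimated at 50000 nM, with a range from 15000 nM to 160000 nM, and most likely the assay will again report only a limit.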

Compound 3, half-maximal inhibitory concentration: > 40000 nM
Compound 3 ended at the assay's limit; the forecaster's own chance of this, stated with the estimate: 65%; the middle value is on the limit's open side.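

In this assay compound 3 gives > 40000 nM, which is a limit of the assay and not a number. The step from compound 2 to compound 3 cannot be read, so the exchange of chloro for methoxy at this position, para to a large group, has no measurable size, but methoxy there does not bring the number back within what the assay resolves. Replacing the 4-chloro-3-(trifluoromethyl)phenyl of compound 1 with 4-methoxyphenyl gives an at least 4.3-fold higher number from compound 1 to compound 3 (0.63 log units; beyond the scatter), so compound 1 now stands apart from two analogues with different para groups, and it alone keeps a number, the rest sitting at: the limit of > 40000 nM in this assay, at which 2 of the 3 values shown sit.

Where compound 2 and compound 3 truly lie relative to each other stays open, as does whether the trifluoromethyl group could restore a number with methoxy in place of chloro. A 4-aminophenyl or 4-carboxyphenyl group on the same nitrogen, or a longer alkoxy chain in place of the methoxy, would test whether this position can move the number at all.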